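The compounds below may be only part of what the source reports. "The series", "measured", "known", "first", "only" and "open" are said of these compounds alone.

In a functional assay on MCF7 cells (Homo sapiens) for cytotoxicity, read by MTT assay, with a stated time of 48 h (a higher number here means a weaker inhibitor, a lower number a stronger inhibitor), compound 3 `COc1ccc(Nc2nc(-c3cccc(F)c3)nc3ccc(F)cc23)cc1` gives 48400 nM, and compound 2 `Fc1cccc(-c2nc(Nc3ccccc3)c3cc(F)ccc3n2)c1` gives 49700 nM, the two lying within the scatter of each other. Compound 1 `Fc1cccc(-c2nc(Nc3ccccc3)c3ccccc3n2)c1` is reported only as a limit, > 50000 nM. Fluoro in place of hydrogen on an aromatic carbon gave a number no higher from compound 1 to compound 2 (the limit leaves the size open). Compound 4 `Fc1cccc(Nc2nc(-c3cccc(F)c3)nc3ccc(F)cc23)c1` differs from compound 3 by 3-fluorophenyl in place of 4-methoxyphenyl on a nitrogen on an aromatic ring, with 3-fluorophenyl in place of 4-methoxyphenyl on a nitrogen on an aromatic ring. The nearest measured step is the methoxy step to compound 3, which gave a 1.0-fold lower number from compound 2 to compound 3 (0.01 log units; within the scatter), so no shift beyond the scatter is expected in this assay. The expected change is a 1.1-fold lower number from compound 3 to compound 4 (0.03 log units; within the scatter). Compound 4 is estimated at 45000 nM, within an expected range of 22000 nM to 65000 nM.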

Compound 4, half-maximal inhibitory concentration: 48700 nM
Beside the measured number, compound 4's estimate is 1.1-fold (0.03 log units) below it, and the stated range covers the measured number.
By their numbers in this assay, from the lowest: compounds 3, 4 and 2 (each within the scatter of the next). At a limit, above all of these: compound 1.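

In this assay, 3-fluorophenyl in place of 4-methoxyphenyl on the nitrogen gave a 1.0-fold higher number from compound 3 to compound 4 (0.00 log units; within the scatter), so replacing the whole aromatic group here moved the number no further than adding methoxy had. Fluoro in place of hydrogen on that ring gave a 1.0-fold lower number from compound 2 to compound 4 (0.01 log units; within the scatter), so neither substituent shifts the number beyond the scatter. Compound 1 is reported only as a limit: the limit of > 50000 nM in this assay, at which 1 of the 4 values shown sits.

From the compounds shown here alone, whether an amine or a carboxylic acid on this ring would move the number beyond the scatter stays open. So does the effect of a longer chain on the nitrogen in place of the ring.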